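Acetyl to Oxan-2-ylcarbonyl on a Shared Core

The compounds below may be only part of what the source reports. "The series", "measured", "known", "first", "only" and "open" are said of these compounds alone.

Compound 1 `CN1CCc2nc(C#Cc3ccccc3)sc2C1`: > 10000 nM
Compound 2 `CC(=O)N1CCc2nc(C#Cc3ccccc3)sc2C1`: 90 nM

In an assay on HEK293 cells for negative allosteric modulation of metabotropic glutamate receptor 5 (Homo sapiens), read by FLIPR, with a stated time of 1 h (on this read-out higher numbers stand for weaker inhibition and lower numbers for stronger inhibition), compound 1 gives only a limit, > 10000 nM. In this assay compound 2 gives 90 nM, the single number shown, while compound 1 sits at the limit of > 10000 nM in this assay, at which 1 of the 2 values shown sits. Among the compounds with values here, the one measured step, an at least 110-fold lower number from compound 1 to compound 2 (2.04 log units; beyond the scatter), concerns the amine nitrogen, not the carbonyl carbon. Compound 3 `O=C(C1CCCCO1)N1CCc2nc(C#Cc3ccccc3)sc2C1` differs from compound 2 by oxan-2-yl in place of methyl on a carbonyl carbon. Within the data shown here, no measured step bears on this change, and the amide is kept, so compound 3 is expected near compound 2, at 150 nM with a range of 40 nM to 600 nM, that is a 1.7-fold higher number from compound 2 to compound 3 (0.22 log units; within the scatter), not beyond the scatter.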

Compound 3, half-maximal inhibitory concentration: > 10000 nM
Compound 3 gave a limit, no number (the forecaster's own chance of this, stated with the estimate: 10%); middle value at least 66-fold (1.82 log units) away from the limit.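

The carbonyl carbon turns out to matter as much as the amine nitrogen: oxan-2-yl in place of methyl there gives an at least 110-fold higher number from compound 2 to compound 3 (2.04 log units; beyond the scatter), so keeping the amide does not by itself preserve the activity of compound 2. The step from compound 1 to compound 3 cannot be read, as both values are limits, and compound 3 stands at a limit rather than a number: the limit of > 10000 nM in this assay, at which 2 of the 3 values shown sit.

On these data alone, whether the loss follows the ring or its oxygen stays open. Ethyl, cyclohexyl or a methoxyethyl chain on the same carbonyl carbon would bear on that.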